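A few compounds are considered here, and "the series" means these few. Any claim that something is new, unique, unknown or untested is made for them only; others in the source may bear on it.

Of the compounds shown here, three have been measured in a functional assay on MGC-803 cells (Homo sapiens) for inhibition, read by MTT assay, with a stated time of 48 h; on this read-out higher numbers stand for weaker inhibition and lower numbers for stronger inhibition. Compound 1 `CCC(=O)N(Cc1ccc(OC)c(O)c1)c1cc(OC)c(OC)c(OC)c1` gives 50 nM in this assay, the lowest of the three numbers. Compound 2 `C/C=C/C(=O)N(Cc1ccc(OC)c(C)c1)c1cc(OC)c(OC)c(OC)c1` gives 14500 nM, and compound 3 `C/C=C/C(=O)N(Cc1ccc(OC)c([N+](=O)[O-])c1)c1cc(OC)c(OC)c(OC)c1` gives 590 nM. Among the measured compounds shown here, compound 2 and compound 3 differ in one place, and that step, a 25-fold lower number from compound 2 to compound 3 (1.39 log units; beyond the scatter), is the only single-change comparison among the measured compounds. Compound 1 sits far from both: against compound 3 its number is lower by a margin beyond the scatter, and against compound 2 by a still wider one.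

Compound 4 `COc1ccc(CN(C(=O)/C=C/CBr)c2cc(OC)c(OC)c(OC)c2)cc1O` is not yet measured. It differs from compound 1 in one place: 3-bromoprop-1-en-1-yl in place of ethyl on a carbonyl carbon. For the measured compounds named here, this change is on the acyl part of the molecule, whereas the one measured step concerns a substituent on an aromatic carbon, so no measured step bears directly on it. Compound 2 and compound 3 carry a different acyl group from compound 1, but they also differ from it on the ring, so their values cannot be traced to the acyl group alone. Going by the values given here, with no guiding step, the expectation for compound 4 is a number close to that of compound 1, with a wide range and no confident direction, that is an expected step of a 1.4-fold higher number from compound 1 to compound 4 (0.15 log units; within the scatter). Compound 4 is therefore estimated at 70 nM, with a range from 15 nM to 350 nM.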

Compound 4, half-maximal inhibitory concentration: 71 nM
For compound 4 the middle estimate is 1.0-fold (0.01 log units) below the measured one, and the stated range covers the measured number.
By their numbers in this assay, from the lowest: compounds 1 and 4 (each within the scatter of the next); then compound 3; then compound 2.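

In this assay, putting 3-bromoprop-1-en-1-yl in place of ethyl on the carbonyl carbon gives a 1.4-fold higher number from compound 1 to compound 4 (0.15 log units; within the scatter), so this read-out does not tell the two compounds apart. Among the compounds shown here, this is the first single-change comparison on the acyl part of the molecule, and it shows that here a group of 4 heavy atoms, with a bromine and a double bond outside aromatic rings, can replace one of 2 heavy atoms while the number stays within the scatter. Nothing available here explains why the two groups read alike.

The change brings in the double bond and the bromine together, so the compounds shown do not separate their contributions; a but-2-enoyl group on the core of compound 1, carrying the double bond without the bromine, would be one way to look at them apart. From the compounds shown here alone, it also remains open whether the same position would give a similar number with quite different groups, such as a longer chain or a chain ending in an amine or a carboxylic acid.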